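This account rests on a few compounds, and the source may have more. Where it says the series, first, only, none or still open, it means among the compounds named here.

Measured compounds:
compound 1, `O=S(=O)(CC1=NCCO1)C1C(c2ccc(Cl)cc2)=NOC1c1ccc(Cl)cc1`, "not active" (no number reported);
compound 2, `Cc1ccc(C2CNN=C2S(=O)(=O)CC2=NCCS2)cc1`, 52.2%;
compound 3, `Cc1ccc(C2CNN=C2S(=O)(=O)CC2=NCCO2)cc1`, 51.4%.

Going by the values given here, in a functional assay, read by Griess assay, with a stated time of 150 min, tested at 100 ug/mL (on this read-out higher numbers stand for a stronger effect at the one concentration tested and lower numbers for a weaker effect), compound 2 and compound 3 give two values that sit within the scatter of each other; the step of a number 0.8 percentage points higher from compound 3 to compound 2 (within the scatter) is the only measured step here. That step corresponds to the change (a group of 5 heavy atoms (3 carbon, 1 nitrogen, 1 sulfur; one five-membered non-aromatic ring with 2 hetero atoms) in place of a group of 5 heavy atoms (3 carbon, 1 nitrogen, 1 oxygen; one five-membered non-aromatic ring with 2 hetero atoms), on a saturated chain carbon bound to a sulfonyl sulfur). Compound 1 gives no number in this assay and is reported only as not active.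

Compound 4, `O=S(=O)(CC1=NCCS1)C1C(c2ccc(Cl)cc2)=NOC1c1ccc(Cl)cc1`, has not yet been measured in this assay. Among the compounds with values here, it differs from compound 1 by a group of 5 heavy atoms (3 carbon, 1 nitrogen, 1 sulfur; one five-membered non-aromatic ring with 2 hetero atoms) in place of a group of 5 heavy atoms (3 carbon, 1 nitrogen, 1 oxygen; one five-membered non-aromatic ring with 2 hetero atoms), on a saturated chain carbon bound to a sulfonyl sulfur, which is the same kind of change as the one from compound 3 to compound 2, and the two place lines read the same. The difference between the core of compound 1 and the core of compound 3 is not broken down here.

Within the data shown here, since the one measured example of this change, a number 0.8 percentage points higher from compound 3 to compound 2 (within the scatter), lies within the scatter, and since compound 1 is reported as not active with no number, compound 4 is expected to behave much like compound 1 in this assay. The estimate for compound 4 is 10%, with an expected range from 0% to 30%.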

Compound 4, a percentage reported as activity, at one concentration (the size of the read-out at that concentration, not a potency): "not active" (no number reported)
Compound 4: no number reported; the estimate stays without a comparison.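

Compound 4 gives "not active" (no number reported) and compound 1 gives "not active" (no number reported), so no step can be read between these two compounds. The compounds shown leave open whether the exchange on a saturated chain carbon bound to a sulfonyl sulfur changes anything on the core of compound 1. No evidence here bears on this result.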